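The compounds below may be only part of what the source reports. "The series", "measured", "known", "first", "only" and "open" are said of these compounds alone.

Three compounds from this series have been run through an assay on isolated protein for inhibition of Rho-associated protein kinase 1 (Homo sapiens), tested at 30 uM; a higher number here means more inhibition at the concentration tested (going by the name of the read-out), a lower number less inhibition. Compound 1, `Cn1cnc2c(Sc3ccc(F)cc3)ncnc21`, gives 6%. Compound 2, `Cn1c(-c2ccccc2)nc2c(Sc3ccc(F)cc3)ncnc21`, differs from compound 1 only by phenyl in place of hydrogen on an aromatic carbon; compound 2 gives 9%, and the step of a number 3 percentage points higher from compound 1 to compound 2 (within the scatter) lies within the scatter. Compound 3, `CSc1ccc(-c2nc3c(Sc4ccccc4)ncnc3n2C)cc1`, gives 0%. Among the compounds with values here, its number sits within the scatter of both compound 1 and compound 2, so the three measured compounds cannot be told apart on the numbers so far.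

The next compound, compound 4, `CSc1ccc(-c2nc3c(Sc4ccc(F)cc4)ncnc3n2C)cc1`, differs from compound 3 in a single place: fluoro in place of hydrogen on an aromatic carbon. Within the data shown here, no measured pair isolates this change. Among the measured compounds shown here, the only measured step, from compound 1 to compound 2, concerns a different position and was itself within the scatter. Compound 1 and compound 2 already carry the 4-fluorophenylsulfanyl group and both give small numbers, which gives no sign that fluoro at this position raises inhibition. Compound 4 is therefore expected to show a number 4 percentage points higher from compound 3 to compound 4 (within the scatter), a step not beyond the scatter. The estimate for compound 4 in this assay is 4%, with a range from -5% to 13%.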

Compound 4, a percentage reported as inhibition, at one concentration (the size of the read-out at that concentration, not a potency): 0%
Compound 4: the middle estimate sits 4 percentage points above what was measured, and the stated range covers the measured number.
By their numbers in this assay, from the lowest: compounds 3, 4, 1 and 2 (each within the scatter of the next).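

In this assay the change from phenylsulfanyl to (4-fluorophenyl)sulfanyl now has a matched pair of its own, and it shows no change at the digits printed from compound 3 to compound 4 (within the scatter) with the 4-(methylsulfanyl)phenyl group in place on the shared core. The two longer routes to compound 4 are just as flat: adding methylsulfanyl on the phenyl group gives a number 9 percentage points lower from compound 2 to compound 4 (within the scatter) and adding the whole 4-(methylsulfanyl)phenyl group gives a number 6 percentage points lower from compound 1 to compound 4 (within the scatter) so none of these three changes stands clear of the scatter. No supporting information is available to interpret these results.

Going by these compounds, all of these comparisons rest on compounds with small numbers at a single concentration, so it remains open whether fluoro at this place would matter in a compound that shows clear inhibition. On these data alone, it is also open whether a different group there, such as an amine or a carboxylic acid, or a longer chain in place of the methyl of the methylsulfanyl group, would move the number beyond the scatter.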